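The source may hold more compounds than are shown below. What is called first, only, known or untested is meant among the compounds shown, and "the series" means these compounds.

Going by the values given here, compound 1 `CCCCCc1ccc(-c2cn(C[C@H](O)[C@H]3OC(=O)C(OCc4ccccc4)=C3OCc3ccccc3)nn2)cc1` is the one member of this set that returns a number in a functional assay on HeLa cells (Homo sapiens) for antiproliferative activity, read by MTT assay, with a stated time of 72 h; a lower number here means a stronger inhibitor, a higher number a weaker inhibitor: compound 1 gives 8390 nM. Compound 2 `CC(C)(C)OC(=O)N1CCN(C(=S)SCc2cn(C[C@H](O)[C@H]3OC(=O)C(OCc4ccccc4)=C3OCc3ccccc3)nn2)CC1` reaches only a limit of the assay, > 100000 nM. Compound 3 `COc1ccccc1-c1cn(C/C=C2\OC(=O)C(OCc3ccccc3)=C2OCc2ccccc2)nn1` likewise returns a limit, > 100000 nM. Among the compounds with values here, the picture is thus shaped by the limit of > 100000 nM in this assay, at which 2 of the 3 values shown sit, and compound 1 stands alone as the sole measured value. Compound 4 `COc1ccc(-c2cn(C[C@H](O)[C@H]3OC(=O)C(OCc4ccccc4)=C3OCc3ccccc3)nn2)cc1` differs from compound 1 by methoxy in place of pentyl on an aromatic carbon. Within the data shown here, no measured pair shows this exchange, so its effect is open. The expectation is a modest weakening, a 2.4-fold higher number from compound 1 to compound 4 (0.38 log units; beyond the scatter), probably beyond the usual scatter but short of the limit. Compound 4 is therefore estimated at 20000 nM, within a range of 5000 nM to 90000 nM.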

Compound 4, half-maximal inhibitory concentration: 16400 nM
For compound 4 the middle estimate is 1.2-fold (0.09 log units) above the measured one; the measured number falls inside the stated range.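

With the core of compound 1 held fixed, methoxy in place of pentyl on the aromatic carbon gives a 2.0-fold higher number from compound 1 to compound 4 (0.29 log units; within the scatter) in this assay. The pentyl chain is therefore not required at this position for a measurable value, and a group carrying a hydrogen-bond acceptor serves there as well. Compound 4 also returns a number rather than a limit, unlike much of the set: the limit of > 100000 nM in this assay, at which 2 of the 4 values shown sit.

This single pair leaves open how an amine or a carboxylic acid at this carbon would behave. It also leaves open what a bare phenyl ring without any such group would give.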